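The source may report more compounds than this note shows. Statements on the series, on what has been measured and on what is new or still open speak of the compounds shown alone.

Compound 1, with the structure `COc1cc2c(cc1O)CCC(C)(CC(=O)O)O2`, carries a carboxy group on a saturated chain carbon bound to a saturated ring carbon. In an ADME assay on SH-SY5Y cells (Homo sapiens) for cytotoxicity, read by MTT assay, with a stated time of 24 h, tested at 3.1 uM (a higher number here means a weaker effect of the compound at the concentration tested, a lower number a stronger effect), compound 1 gives 100%. Compound 2, `COc1cc2c(cc1O)CCC(C)(CC(=O)N[C@@H](C)C(=O)O)O2`, gives 100% in this assay, so compound 1 is level with compound 2, and the two stand together as the highest of the three numbers. Compound 3, `COc1cc2c(cc1O)CCC(C)(CC(=O)N[C@H](C(=O)O)C(C)C)O2`, gives 79.1%, the lowest value.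

Compound 4, `COc1cc2c(cc1O)CCC(C)(CC(N)C(=O)O)O2`, differs from compound 1 in one place: amino(carboxy)methyl in place of carboxy on a saturated chain carbon bound to a saturated ring carbon. For the measured compounds named here, two measured steps bear on this. The step of no change at the digits printed from compound 1 to compound 2 (within the scatter) shows that attaching a small amino-acid unit left the value unchanged, while a number 20.9 percentage points lower from compound 1 to compound 3 (beyond the scatter) shows that a bulkier amino-acid unit lowered it modestly, as did a number 20.9 percentage points lower from compound 2 to compound 3 (beyond the scatter). The unit entering in compound 4 is smaller than either of those, so little movement beyond the scatter is expected.

Compound 4 is therefore expected to give about 96% in this assay, between 84% and 100%, which means an expected step of a number 4 percentage points lower from compound 1 to compound 4 (within the scatter).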

Compound 4, a percentage reported as activity, at one concentration (the size of the read-out at that concentration, not a potency): 100%
Estimate against measurement, compound 4: 4 percentage points below; low and high end bracket the measured number.
By their numbers in this assay, from the lowest: compound 3; then compounds 1, 2 and 4 (each within the scatter of the next).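

In this assay, amino(carboxy)methyl in place of carboxy on a saturated chain carbon bound to a saturated ring carbon gives no change at the digits printed from compound 1 to compound 4 (within the scatter). The earlier steps shown here changed only the hydroxy on the carbonyl carbon, each forming an amide, whereas this one adds an amino group to the chain with no amide involved, and the read-out still does not move. No measurement available here accounts for this result.

From the compounds shown here alone, what a methyl ester in place of the carboxy group, or an acetamide in place of the amino group, would do at this position remains open. Going by these compounds, it is also open whether a longer chain carrying both the amino and carboxy groups would leave the value unchanged, as amino(carboxy)methyl does.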